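The source may hold more compounds than are shown below. What is called first, only, known or untested is meant among the compounds shown, and "the series" means these compounds.

Two compounds share one core and differ only in the group on the benzyl arm. In a functional assay on HeLa cells (Homo sapiens) for antiproliferative activity, read by sulforhodamine B assay, with a stated time of 48 h (a lower number here means a stronger inhibitor of growth, a higher number a weaker inhibitor of growth), compound 1 `O=C(NCc1cn(Cc2ccc(Cl)cc2)nn1)c1cn(-c2ccccc2)nc1-c1ccc(Cl)cc1` gives 470 nM. In this assay, going by the values given here, compound 2 `O=C(NCc1cn(Cc2ccc(C(F)(F)F)cc2)nn1)c1cn(-c2ccccc2)nc1-c1ccc(Cl)cc1` gives 1900 nM, the higher of the two numbers; the sole measured step is a 4.0-fold higher number from compound 1 to compound 2 (0.61 log units; beyond the scatter). Compound 3 `COc1ccc(Cn2cc(CNC(=O)c3cn(-c4ccccc4)nc3-c3ccc(Cl)cc3)nn2)cc1OC` carries 3,4-dimethoxyphenyl in place of 4-(trifluoromethyl)phenyl on a saturated chain carbon bound to an aromatic nitrogen. Among the compounds with values here, no measured step exchanges such a group, so that one step only shows how far this position can move the number. Compound 3 is expected near 900 nM, within 250 nM to 3500 nM. The step implied by this estimate is a 2.1-fold lower number from compound 2 to compound 3 (0.32 log units; beyond the scatter), and it is expected with wide uncertainty.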

Compound 3, concentration for 50% growth inhibition: 200 nM
Beside the measured number, compound 3's estimate is 4.5-fold (0.65 log units) above it; the measured number lies below the stated range.
By their numbers in this assay, from the lowest: compound 3; then compound 1; then compound 2.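

In this assay, the earlier pair showed only that the benzyl arm can move the number; now 3,4-dimethoxyphenyl shows that it can also bring stronger growth inhibition, with a 9.5-fold lower number from compound 2 to compound 3 (0.98 log units; beyond the scatter) and a 2.4-fold lower number from compound 1 to compound 3 (0.37 log units; beyond the scatter). Both steps lie beyond the scatter, so this group beats both 4-chlorophenyl and 4-(trifluoromethyl)phenyl here. Nothing measured explains this difference. On these data alone, whether a single methoxy group would do as well remains open. So does how an amine or a carboxylic acid on this ring would behave.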